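Extending a Hydroxyphenyl Amide to a Cinnamyl Hydroxamate

The compounds below may be only part of what the source reports. "The series", "measured", "known", "first", "only" and "open" are said of these compounds alone.

The series shares the core of compound 1, which carries a short hydroxyethyl amide, `C=C(CC)C(=O)c1ccc(OCC(=O)NCCO)c(Cl)c1Cl`. In a functional assay on CLL cells (Homo sapiens) for cytotoxicity, read by MTT assay, with a stated time of 48 h (a higher number here means that more compound is needed for the effect, a lower number that less compound is needed), compound 1 gives only a limit, > 25000 nM, and not a number. Compound 2 replaces that chain with a methoxycarbonylphenyl ring, `C=C(CC)C(=O)c1ccc(OCC(=O)Nc2ccc(C(=O)OC)cc2)c(Cl)c1Cl`, and in this assay compound 2 gives 4100 nM. Compound 3 carries a 4-hydroxyphenyl group instead, `C=C(CC)C(=O)c1ccc(OCC(=O)Nc2ccc(O)cc2)c(Cl)c1Cl`, and in this assay compound 3 gives 6400 nM. Among the two numbers shown, compound 3 stands highest, with compound 2 nearest and within the scatter; the remaining value for compound 1 is a limit. The step of an at least 3.9-fold lower number from compound 1 to compound 3 (0.59 log units; beyond the scatter) is the only one beyond the scatter, while a 1.6-fold higher number from compound 2 to compound 3 (0.19 log units; within the scatter) stays within it.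

Compound 4 is the next member, `C=C(CC)C(=O)c1ccc(OCC(=O)Nc2ccc(/C=C/C(=O)NO)cc2)c(Cl)c1Cl`. It differs from compound 3 by 2-(hydroxycarbamoyl)ethenyl in place of hydroxy on an aromatic carbon. The step from compound 2 to compound 3 is the one that bears on this change, since it too swaps the group on the aromatic carbon of the phenyl amide, and it was within the scatter. Compound 4 is therefore expected to give a number near that of compound 3, with at most a modest lowering, a 2.1-fold lower number from compound 3 to compound 4 (0.33 log units; beyond the scatter). The estimate for compound 4 in this assay is 3000 nM, ranging from 700 nM to 12000 nM.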

Compound 4, half-maximal effective concentration: 2600 nM
For compound 4 the middle estimate is 1.2-fold (0.06 log units) above the measured one; the measured number falls inside the stated range.
By their numbers in this assay, from the lowest: compounds 4, 2 and 3 (each within the scatter of the next, the first and the last beyond it). At a limit, above all of these: compound 1.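

Among the compounds shown here, at this aromatic carbon, para to a large group, the six heavy atoms of 2-(hydroxycarbamoyl)ethenyl are accepted in this assay with no loss of effect, and replacing hydroxy with this group gives the first step at this place that lies beyond the scatter, a 2.5-fold lower number from compound 3 to compound 4 (0.39 log units; beyond the scatter), although it is only a modest one. Against methoxycarbonyl, however, the same group gives a 1.6-fold lower number from compound 2 to compound 4 (0.20 log units; within the scatter), so the change stands out from hydroxy but cannot be told apart from the ester, and the longer group sets no clear new level at this place. Nothing measured here gives a reason for either step.

The compounds shown leave open whether the step belongs to the hydroxycarbamoyl end or to the ethenyl link, which a carboxylic acid on the same ethenyl chain, or the hydroxycarbamoyl group on a saturated ethyl chain, would help to separate. They also leave open whether the same group would behave alike on the hydroxyethyl amide of compound 1, or with an amine at this aromatic carbon as a further comparison.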